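The source may report more compounds than this note shows. Statements on the series, on what has been measured and on what is new or still open speak of the compounds shown alone.

Measured so far:
compound 1 `CCCN(c1nccc(-c2c(OC)cc(OC)cc2OC)n1)C1(c2ccsc2)CC1`, 2000 nM
compound 2 `CCCN(c1nccc(-c2c(OC)cc(OC)cc2OC)n1)C1(c2ccoc2)CC1`, 700 nM

In an assay on CHO cells for displacement of a labelled ligand from corticotropin-releasing factor receptor 1 (Homo sapiens) (a higher number here means a weaker inhibitor, a lower number a stronger inhibitor), compound 2 gives the lower of the two numbers, with compound 1 above it by a 2.9-fold lower number from compound 1 to compound 2 (0.46 log units; beyond the scatter). Compound 3 `CCCN(c1nccc(-c2c(OC)cc(OC)cc2OC)n1)C1CCCC1` is the next step: cyclopentyl in place of 1-(furan-3-yl)cyclopropyl on a nitrogen on an aromatic ring. Among the compounds with values here, the one measured step only swapped furan-3-yl for thiophen-3-yl and kept the three-membered ring, so it does not bear directly on removing both. Without a measured guide, a weaker result is expected for compound 3, a 2.9-fold higher number from compound 2 to compound 3 (0.46 log units; beyond the scatter), with a wide range: 2000 nM, between 500 nM and 8000 nM.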

Compound 3, inhibition constant: 2200 nM
The estimate for compound 3 lay 1.1-fold (0.04 log units) below the measured number; the measured number falls inside the stated range.
By their numbers in this assay, from the lowest: compound 2; then compounds 1 and 3 (each within the scatter of the next).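

In this assay, putting cyclopentyl in place of the whole 1-(furan-3-yl)cyclopropyl group on the nitrogen gives a real loss (a 3.1-fold higher number from compound 2 to compound 3 (0.50 log units; beyond the scatter)), so the furan-bearing group is better here than this plain carbon ring. Cyclopentyl in place of 1-(thiophen-3-yl)cyclopropyl changes nothing measurable (a 1.1-fold higher number from compound 1 to compound 3 (0.04 log units; within the scatter)), so the thiophene-bearing group holds no such advantage. No measurement at hand explains this difference between the two groups. Still open, as far as these compounds go, is how a bare cyclopropyl, or a phenyl on that three-membered ring, would compare with the furan-bearing group.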